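The source may report more compounds than this note shows. Statements on the series, on what has been measured and on what is new or still open speak of the compounds shown alone.

Compound 3 `OC(CCn1nc2c(Br)c(Br)c(Br)c(Br)c2n1)c1ccccc1` stands highest of the three measured compounds in a functional assay on CCRF-CEM cells (Homo sapiens) for antiproliferative activity, read by MTT assay, with a stated time of 24 h, tested at 12.5 uM (a lower number here means a stronger effect, a higher number a weaker effect of the compound at the concentration tested), where compound 3 gives 122%. Compound 1 `COc1cccc(C(O)CCn2nc3c(Br)c(Br)c(Br)c(Br)c3n2)c1` gives 110% in this assay, and compound 2 `OC(CCn1nc2c(Br)c(Br)c(Br)c(Br)c2n1)c1cccc(Cl)c1` gives 110% in this assay. Compound 4 `OC(CCn1nc2c(Br)c(Br)c(Br)c(Br)c2n1)c1ccc(Cl)cc1` differs from compound 3 by chloro in place of hydrogen on an aromatic carbon. The measured steps that bear on this change are a number 12 percentage points higher from compound 2 to compound 3 (beyond the scatter) and a number 12 percentage points higher from compound 1 to compound 3 (beyond the scatter); both show that removing a group from the aromatic ring of compound 3 raised the number modestly, so placing a group on that ring is expected to lower it by a similar, modest amount. Compound 4 is therefore estimated at 110%, within 96% to 124%, which amounts to an expected step of a number 12 percentage points lower from compound 3 to compound 4 (beyond the scatter).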

Compound 4, a percentage reported as activity, at one concentration (the size of the read-out at that concentration, not a potency): 105%
The estimate for compound 4 lay 5 percentage points above the measured number, within the range that was stated.
By their numbers in this assay, from the lowest: compounds 4, 1 and 2 (each within the scatter of the next); then compound 3.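

Para to a large group on the phenyl ring, chloro gives a number 17 percentage points lower from compound 3 to compound 4 (beyond the scatter) in this assay, showing that a ring group at this place also lowers the number relative to the unsubstituted phenyl of compound 3. The 4-chlorophenyl ring is not separated from the other substituted rings, with a number 5 percentage points lower from compound 2 to compound 4 (within the scatter) and a number 5 percentage points lower from compound 1 to compound 4 (within the scatter). No measurement is available that explains this effect. On these data alone, what an amine or a carboxylic acid on this ring would do remains open, as does the effect of a longer chain between the core and the ring.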